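Turning One Ring Stereocentre in a Weak Receptor Binder

The source may report more compounds than this note shows. Statements on the series, on what has been measured and on what is new or still open speak of the compounds shown alone.

Compound 1, `O=C(O)C[C@@]1(O)CCC[C@H](/C=C/C(O)CCCCc2ccccc2)C1`, gives > 10000 nM; 1500 nM (2 entries).
Compound 2, `CN(C)OC(=O)C[C@]1(O)CCC[C@H](/C=C/C(O)CCCCc2ccccc2)C1`, gives > 10000 nM.

The measurements come from an assay for inhibition of leukotriene B4 receptor (Homo sapiens); a lower number here means a stronger inhibitor, a higher number a weaker inhibitor. For compound 1 the two entries are not alike: one of them is a limit of the assay rather than a number, the other is a number, as the lines the several entries of compound 1 in this assay, > 10000 nM; 1500 nM (2 entries) and the limit of > 10000 nM in this assay, at which 1 of the 2 values shown sits, show. For compound 2 the only entry in this assay is a limit, not a number, so compound 2 stands as a weak binder whose true value is not pinned down.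

Compound 3, `CN(C)OC(=O)C[C@@]1(O)CCC[C@H](/C=C/C(O)CCCCc2ccccc2)C1`, has not been measured yet. Set against compound 2 it differs in this way: the two compounds have the same atoms and bonds; at least one stereo element is drawn with a configuration in one of them and without one in the other: 1 of 4 stereo elements differ; a stereocentre at a saturated ring carbon is drawn S in compound 2 and R in compound 3. Going by the values given here, no measured pair in this set reports what such a turn of a ring stereocentre does in this assay, so there is no step to lean on. From compound 2, which sits only at a limit, the step of an at least 1.2-fold lower number from compound 2 to compound 3 (0.09 log units; that floor lies within the scatter) is expected to stay roughly within the scatter, with a slight lean toward a measurable number. Compound 3 is therefore estimated at 8000 nM, in a range from 2000 nM to 30000 nM.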

Compound 3, half-maximal inhibitory concentration: 80 nM
Beside the measured number, compound 3's estimate is 100-fold (2.00 log units) above it, and the stated range ends above it.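

In this assay, turning one stereocentre at a saturated ring carbon from S to R, with every atom and bond left in place, gives an at least 120-fold lower number from compound 2 to compound 3 (2.09 log units; beyond the scatter). The earlier compounds shown here could not show this, as they held no measured pair with such a turn, and this pair shows that the configuration at this one carbon can decide whether binding registers as a clear number in this assay. Compound 2 gives > 10000 nM, which is a limit of the assay, so the step is only a floor and the real gap may be wider, because one end of the comparison has no number: the limit of > 10000 nM in this assay, at which 1 of the 3 values shown sits.

The compounds shown leave open whether the same turn matters as much when a methyl ester or a primary amide takes the place of the dimethylamino-oxy ester, and whether a longer chain in place of the phenylbutyl end would change the picture. How the configuration is drawn also needs checking before the pair is read as a clean swap of one stereocentre for its mirror arrangement, and the record itself flags this: the fact that one of compounds 2 and 3 is drawn with a defined configuration and the other without, at the place where they differ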